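Trifluoromethyl for Methoxy at an Inactive Starting Point

The source may hold more compounds than are shown below. What is called first, only, known or untested is meant among the compounds shown, and "the series" means these compounds.

Compound 1, `COc1ccccc1NC(=S)N/N=C/c1ccc2ccccc2n1`, was tested in a functional assay on HeLa cells (Homo sapiens) for antiproliferative activity, read by sulforhodamine B assay, with a stated time of 72 h; a lower number here means a stronger inhibitor, a higher number a weaker inhibitor. Here compound 1 returns only a limit of the assay, > 100000 nM, and not a number. Compound 3, `COc1ccc(C)cc1NC(=S)N/N=C/c1ccc2ccccc2n1`, which carries a methyl in place of a hydrogen on an aromatic carbon, likewise returns only a limit in this assay, > 100000 nM. The step from compound 1 to compound 3 is accordingly a step that the two limits leave unreadable from compound 1 to compound 3. Compound 2, `CN(C)C(=S)N/N=C/c1cc2cccnc2s1`, built on a different core, gives 48400 nM in this assay. The set is dominated by the limit of > 100000 nM in this assay, at which 2 of the 3 values shown sit.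

Compound 4, `FC(F)(F)c1ccccc1NC(=S)N/N=C/c1ccc2ccccc2n1`, differs from compound 1 in a single place: trifluoromethyl in place of methoxy on an aromatic carbon. Among the compounds with values here, no measured step bears on this exact change, and the one step on the same core, from compound 1 to compound 3, has no readable size. No direction can be taken from the data. The expected step in this assay is a number no higher from compound 1 to compound 4 (the limit leaves the size open), within the scatter. For compound 4 the estimate in this assay is 100000 nM, with a range from 30000 nM to 300000 nM, and another limit is the likeliest outcome.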

Compound 4, half-maximal inhibitory concentration: 18800 nM
For compound 4 the middle estimate is 5.3-fold (0.73 log units) above the measured one; measured number outside the range, below it.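

In this assay, trifluoromethyl in place of methoxy on this aromatic carbon, ortho to a large group, gives an at least 5.3-fold lower number from compound 1 to compound 4 (0.72 log units; beyond the scatter), so this position does respond to a change of group. Compound 1 gives > 100000 nM, which is a limit of the assay and not a number, so the step sets only a minimum size. On the shared core, compound 4 is the only compound shown with a readable number, while the step to compound 3 cannot be read, and the limit still marks the set: the limit of > 100000 nM in this assay, at which 2 of the 4 values shown sit.

The full size of the step stays open, and the compounds shown do not separate the removal of methoxy from the arrival of trifluoromethyl. As far as these compounds go, whether a chlorine, a nitrile or a carboxylic acid at this place would also give a readable number is equally open.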